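Acetate in place of chromone ester: cytotoxicity outlook

The source may report more compounds than this note shows. Statements on the series, on what has been measured and on what is new or still open speak of the compounds shown alone.

In an ADME assay on HepG2 2.2.15 cells (Homo sapiens) for cytotoxicity, read by MTT assay (a higher number here means that more compound is tolerated, a lower number that less compound is tolerated), compound 3 `C=C1CC[C@@H]2[C@](C)(COC(=O)c3cc(=O)c4ccccc4o3)[C@H](O)CC[C@@]2(C)[C@@H]1/C=C/C1=CCOC1=O` gives 171000 nM. Compound 2 `C=C1CC[C@@H]2[C@](C)(COC(=O)c3ccco3)[C@H](O)CC[C@@]2(C)[C@@H]1/C=C/C1=CCOC1=O` gives 92000 nM in this assay, and the two are separated by a 1.9-fold higher number from compound 2 to compound 3 (0.27 log units; within the scatter), so their numbers cannot be told apart. Compound 1 `C=C1CC[C@@H]2[C@](C)(COC(=O)/C=C/c3cccc(OC)c3)[C@H](O)CC[C@@]2(C)[C@@H]1/C=C/C1=CCOC1=O` reaches only a limit of this assay, > 1970000 nM. That limit is the limit of > 1970000 nM in this assay, at which 1 of the 3 values shown sits, so the steps of an at least 21-fold lower number from compound 1 to compound 2 (1.33 log units; beyond the scatter) and an at least 11-fold lower number from compound 1 to compound 3 (1.06 log units; beyond the scatter) are bounded on one side only. Compound 4 `C=C1CC[C@@H]2[C@](C)(COC(C)=O)[C@H](O)CC[C@@]2(C)[C@@H]1/C=C/C1=CCOC1=O` is not yet measured in this assay. The change is one carbon atom in place of a group of 11 heavy atoms (9 carbon, 2 oxygen; one six-membered aromatic ring of carbon only, one six-membered aromatic ring with 1 hetero atom), on a carbonyl carbon. For the measured compounds named here, the measured steps all alter the group on the carbonyl carbon: the two from compound 1 are large, the one between compound 2 and compound 3 is within the scatter, and none removes the aromatic group altogether. For compound 4 a step of a 2.0-fold higher number from compound 3 to compound 4 (0.31 log units; beyond the scatter) is expected, toward a higher number, with wide uncertainty and a real chance that only a limit is reported. Compound 4 is estimated at 350000 nM, between 100000 nM and 2000000 nM.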

Compound 4, half-maximal cytotoxic concentration: 225000 nM
Compound 4: the middle estimate sits 1.6-fold (0.19 log units) above what was measured; low and high end bracket the measured number.
By their numbers in this assay, from the lowest: compounds 2, 3 and 4 (each within the scatter of the next, the first and the last beyond it). At a limit, above all of these: compound 1.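

In this assay, methyl on the carbonyl carbon gives a 1.3-fold higher number from compound 3 to compound 4 (0.12 log units; within the scatter), so removing the aromatic group altogether leaves no difference that can be told apart from compound 3, while methyl against furan-2-yl gives a 2.4-fold higher number from compound 2 to compound 4 (0.39 log units; beyond the scatter), a modest step. An aromatic group at this position is therefore not required for numbers of this order, although compound 2 lies beyond the scatter from compound 4. The 2-(3-methoxyphenyl)ethenyl ester compound 1 remains apart, with an at least 8.7-fold lower number from compound 1 to compound 4 (0.94 log units; beyond the scatter), and this step is bounded on one side only, compound 1 being at a limit: the limit of > 1970000 nM in this assay, at which 1 of the 4 values shown sits.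

The compounds shown leave open whether the ethenyl link or the methoxy group sets compound 1 apart. From the compounds shown here alone, how a carboxylic acid, an amine or a longer alkyl chain at this position would behave also remains open.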